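A few compounds are considered here, and "the series" means these few. Any claim that something is new, unique, unknown or untested is made for them only; others in the source may bear on it.

Measured in an assay on isolated protein for displacement of a labelled ligand from Adrenergic receptor alpha-1 (Rattus norvegicus); on this read-out higher numbers stand for weaker inhibition and lower numbers for stronger inhibition:

Compound 1 `COc1cc2nc(N3CCC(C(=O)NCC4CC4)CC3)nc(N)c2cc1OC` gives 0.9 nM.
Compound 2 `COc1cc2nc(N3CCC(C(=O)NCCO)CC3)nc(N)c2cc1OC` gives 1.73 nM.
Compound 3 `COc1cc2nc(N3CCC(C(=O)Nc4ccccc4)CC3)nc(N)c2cc1OC` gives 0.47 nM.

Compound 3 carries the lowest number of the three, but its gap to compound 1 is within the scatter, so the two cannot be ordered; only its gap to compound 2 is beyond the scatter, as a 3.7-fold lower number from compound 2 to compound 3 (0.57 log units; beyond the scatter) shows. Compound 4 `COc1cc2nc(N3CCC(C(=O)N(C)Cc4ccccc4)CC3)nc(N)c2cc1OC` differs from compound 3 in one place: benzyl(methyl)amino in place of anilino on a carbonyl carbon.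

The steps measured so far all vary the group on the amide, and they were small: a 1.9-fold lower number from compound 1 to compound 3 (0.28 log units; within the scatter), a 1.9-fold higher number from compound 1 to compound 2 (0.28 log units; within the scatter), and the modest 3.7-fold lower number from compound 2 to compound 3 (0.57 log units; beyond the scatter). For the measured compounds named here, none of them exchanges anilino for benzyl(methyl)amino, so no direct precedent exists. Given how little the amide substituent has moved the number across compounds 1, 2 and 3, compound 4 is expected to stay close to compound 3, with a step of a 2.1-fold higher number from compound 3 to compound 4 (0.33 log units; beyond the scatter), not clearly beyond the scatter. Compound 4 is therefore estimated at 1 nM, in a range from 0.3 nM to 3.5 nM.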

Compound 4, inhibition constant: 0.2 nM
The estimate for compound 4 lay 5.0-fold (0.70 log units) above the measured number; the measured number lies below the stated range.
By their numbers in this assay, from the lowest: compound 4; then compounds 3, 1 and 2 (each within the scatter of the next, the first and the last beyond it).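

Swapping anilino for benzyl(methyl)amino on the carbonyl carbon removes the amide hydrogen, and in this assay this gives a 2.4-fold lower number from compound 3 to compound 4 (0.37 log units; beyond the scatter) as a modest step, so this position does not need that hydrogen for a low number. For the compounds shown here, the same group also gives a 4.5-fold lower number from compound 1 to compound 4 (0.65 log units; beyond the scatter) and an 8.7-fold lower number from compound 2 to compound 4 (0.94 log units; beyond the scatter) in this read-out, which makes compound 4 the strongest of the four, the only one whose steps to all the others lie beyond the scatter. No measurement here explains why this change lowers the number.

The change alters two things at once, adding a methyl on the amide nitrogen and a carbon between that nitrogen and the phenyl ring, and these compounds cannot separate the two. Benzylamino or methyl(phenyl)amino on the same carbonyl carbon would tell them apart, while a longer chain such as methyl(2-phenylethyl)amino would show whether the trend continues.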